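A few compounds are considered here, and "the series" means these few. Any claim that something is new, unique, unknown or untested is made for them only; others in the source may bear on it.

Measured in a functional assay on MCF-10A cells (Homo sapiens) for antiproliferative activity, with a stated time of 48 h; a lower number here means that less compound is needed, a higher number that more compound is needed for the effect:
Compound 1 `COc1ccc2nc(C)cc(NCc3ccc(C)cc3)c2c1`: 22400 nM
Compound 2 `COc1ccc2nc(C)cc(NCc3cccc(F)c3)c2c1`: 14700 nM
Compound 3 `COc1ccc2nc(C)cc(NCc3ccccc3F)c2c1`: 17000 nM

Compound 2 is not separated from either of the other two compounds on these numbers. The comparison with its nearest neighbour gives a 1.2-fold higher number from compound 2 to compound 3 (0.06 log units; within the scatter), and the comparison with its furthest gives a 1.5-fold lower number from compound 1 to compound 2 (0.18 log units; within the scatter). The next compound, compound 4 `COc1ccc2nc(C)cc(NCc3cccc(N(C)C)c3)c2c1`, keeps the core of compound 2 and differs in one place: dimethylamino in place of fluoro on an aromatic carbon. In words, this is dimethylamino in place of fluoro on an aromatic carbon, meta to a large group.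

Three measured steps alter substitution on this same aromatic ring. Besides the two already given, there is a 1.3-fold lower number from compound 1 to compound 3 (0.12 log units; within the scatter). All three are small, so this series has so far shown little response in this assay to changes on this ring. None of the three compounds carries a dimethylamino group, however, so the data offer no direct measure of this replacement, and the range has to stay wide. On this basis, no step beyond the scatter is expected, and the estimated change is a 1.1-fold higher number from compound 2 to compound 4 (0.04 log units; within the scatter). Compound 4 is expected at 16000 nM. The estimated range for compound 4 runs from 7000 nM to 35000 nM.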

Compound 4, half-maximal effective concentration: 14000 nM
The estimate for compound 4 lay 1.1-fold (0.06 log units) above the measured number; measured number inside the range.
By their numbers in this assay, from the lowest: compounds 4, 2, 3 and 1 (each within the scatter of the next).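

In this assay, dimethylamino in place of fluoro on an aromatic carbon, meta to a large group, gives a 1.1-fold lower number from compound 2 to compound 4 (0.02 log units; within the scatter). The earlier steps shown here on this ring involved only fluoro and methyl, whereas here the entering group brings nitrogen into this place, with 3 heavy atoms and 1 hydrogen-bond acceptor against 1 heavy atom and 0 hydrogen-bond acceptors for the leaving fluoro, and still the number does not move beyond the scatter. Nothing available bears on why this larger exchange leaves the number where it is.

The compounds shown leave open whether any group at this carbon can separate a compound from the others, for instance a carboxylic acid, an amide or a longer chain ending in a primary amine, since all four compounds so far lie within the scatter of their neighbours in the order of their numbers. They also leave open how dimethylamino would behave on the other carbons of this ring, as it appears here in only one place.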